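Arylethynyl for iodo on the core of compound 2

The compounds below may be only part of what the source reports. "The series", "measured", "known", "first", "only" and "open" are said of these compounds alone.

The measured compounds are:
compound 1, `CONc1nc(C#CCC(C)O)nc2c1ncn2[C@@H]1O[C@H](CO)[C@@H](O)[C@H]1O`, 5.4 nM in an assay on CHO cells for displacement of a labelled ligand from adenosine receptor A3 (Homo sapiens); on this read-out higher numbers stand for weaker inhibition and lower numbers for stronger inhibition;
compound 2, `CNC(=O)[C@H]1O[C@@H](n2cnc3c(NOC)nc(I)nc32)[C@H](O)[C@@H]1O`, 1.7 nM in this assay;
compound 3, `CCNC(=O)[C@H]1O[C@@H](n2cnc3c(NOC)nc(I)nc32)[C@H](O)[C@@H]1O`, 2.8 nM in this assay.

Compound 2 gives the lowest number of the three in this assay. For the measured compounds named here, its nearest neighbour is compound 3, and that step, a 1.6-fold higher number from compound 2 to compound 3 (0.22 log units; within the scatter), lies within the scatter; compound 1 is furthest, with a higher number that lies beyond the scatter, though compound 1 differs from compound 2 in more than one place, so no single step is counted between them.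

The unmeasured compound 4, `CNC(=O)[C@H]1O[C@@H](n2cnc3c(NOC)nc(C#Cc4ccc(F)cc4)nc32)[C@H](O)[C@@H]1O`, differs from compound 2 in one place: 2-(4-fluorophenyl)ethynyl in place of iodo on an aromatic carbon. Going by the values given here, no measured step changes this part of the core; the only counted step, from compound 2 to compound 3, alters the amide substituent and stays within the scatter. Compound 1, which carries a different alkynyl chain on its core, gives 5.4 nM, but it is not a clean comparison. The expectation for compound 4 in this assay is therefore a step of about a 1.8-fold higher number from compound 2 to compound 4 (0.25 log units; within the scatter), not clearly beyond the scatter. Compound 4 is estimated at 3 nM, within 0.8 nM to 12 nM.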

Compound 4, inhibition constant: 1.9 nM
Estimate against measurement, compound 4: 1.6-fold (0.20 log units) above; the range from low to high includes it.
By their numbers in this assay, from the lowest: compounds 2, 4, 3 and 1 (each within the scatter of the next, the first and the last beyond it).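

In this assay, for the compounds shown here, putting 2-(4-fluorophenyl)ethynyl in place of iodo on the aromatic carbon between two ring nitrogen atoms gives a 1.1-fold higher number from compound 2 to compound 4 (0.05 log units; within the scatter) and leaves compound 2 and compound 4 indistinguishable, a first reading at a position that the only earlier step, confined to the amide substituent, did not reach. The exchange is a large one in structural terms: a single iodine atom leaves, while 9 heavy atoms enter, carrying a six-membered aromatic ring of carbon only and a triple bond outside aromatic rings. On the core of compound 2, then, this position accepts both the single atom and the much larger arylethynyl group with no difference beyond the scatter, although nothing available here explains why the two read alike.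

Open, going by these compounds, is whether this holds for other groups at the same carbon, such as unsubstituted phenylethynyl, a pyridylethynyl group, a longer alkynyl chain or an amine. Also open, on these data alone, is whether 2-(4-fluorophenyl)ethynyl reads the same way when paired with the ethyl amide of compound 3.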